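From compound 3 to compound 4: amino to methyl

This account rests on a few compounds, and the source may have more. Where it says the series, first, only, none or still open, it means among the compounds named here.

In a physicochemical assay for lipophilicity (on this read-out higher numbers stand for higher lipophilicity and lower numbers for lower lipophilicity), compound 1 (`COc1ccc(CN(CCN(C)C)c2ccc(Cl)cc2)cc1`) gives 4.47, compound 2 (`COc1ccc(CN(CCN(C)C)c2ccc(C)cc2)cc1`) gives 4.43, and compound 3 (`COc1ccc(CN(CCN(C)C)c2ccc(N)cn2)cc1`) gives 2.56, the lowest of the three. Compound 4 (`COc1ccc(CN(CCN(C)C)c2ccc(C)cn2)cc1`) carries methyl in place of amino on an aromatic carbon. Within the data shown here, three measured steps bear on this change. The methyl-for-chloro step is a number 0.04 log units lower from compound 1 to compound 2 (within the scatter). The first large step, with its 5-aminopyridin-2-yl group, is a number 1.91 log units lower from compound 1 to compound 3 (beyond the scatter). Compound 4 keeps the ring nitrogen, so only part of the size of the second large step, a number 1.87 log units lower from compound 2 to compound 3 (beyond the scatter), is expected back. The expected step is a number 1.24 log units higher from compound 3 to compound 4 (beyond the scatter). Compound 4 is estimated at 3.8, with an expected range of 3.3 to 4.3.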

Compound 4, partition coefficient: 3.79
For compound 4 the middle estimate is 0.01 log units above the measured one; measured number inside the range.
By their numbers in this assay, from the lowest: compound 3; then compound 4; then compounds 2 and 1 (each within the scatter of the next).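

In this assay, the swap at this position on the ring with one nitrogen is large on its own (a number 1.23 log units higher from compound 3 to compound 4 (beyond the scatter)). With methyl in place at this position, replacing 4-methylphenyl with 5-methylpyridin-2-yl gives only a modest step (a number 0.64 log units lower from compound 2 to compound 4 (beyond the scatter)), and replacing 4-chlorophenyl gives a modest one too (a number 0.68 log units lower from compound 1 to compound 4 (beyond the scatter)), so most of the large drop to compound 3 goes with amino rather than with the ring nitrogen. No supporting measurement explains these steps. As far as these compounds go, it remains open whether a hydroxyl or a nitrile at this position would fall nearer compound 3 or compound 4.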